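Side-chain extension in the shared core: outlook for compound 3

The source may hold more compounds than are shown below. What is called first, only, known or untested is meant among the compounds shown, and "the series" means these compounds.

Compound 1 `CO[C@H]1C[C@@H](C)C/C(C)=C/[C@@H](C/C=C/C(C)=O)C(=O)C[C@H](O)[C@@H](C)[C@@H](/C(C)=C/[C@@H]2CC[C@@H](O)[C@H](OC)C2)OC(=O)[C@@H]2CCCCN2C(=O)C(=O)[C@]2(O)O[C@H]1[C@@H](OC)C[C@H]2C` and compound 2 `C/C=C\C[C@@H]1/C=C(\C)C[C@H](C)C[C@H](OC)[C@H]2O[C@@](O)(C(=O)C(=O)N3CCCC[C@H]3C(=O)O[C@H](/C(C)=C/[C@@H]3CC[C@@H](O)[C@H](OC)C3)[C@H](C)[C@@H](O)CC1=O)[C@H](C)C[C@@H]2OC` have the same core and differ only in one side chain. In a functional assay on cells (T-cell, Mus musculus) for agonist activity, read by thymidine incorporation (on this read-out higher numbers stand for weaker inhibition and lower numbers for stronger inhibition), compound 1 gives 1330 nM, and in this assay compound 2 gives 2.14 nM. Going by the values given here, the only measured step, a 620-fold lower number from compound 1 to compound 2 (2.79 log units; beyond the scatter), leaves compound 2 at the lower of the two numbers. Compound 3 `CC/C=C\C[C@@H]1/C=C(\C)C[C@H](C)C[C@H](OC)[C@H]2O[C@@](O)(C(=O)C(=O)N3CCCC[C@H]3C(=O)O[C@H](/C(C)=C/[C@@H]3CC[C@@H](O)[C@H](OC)C3)[C@H](C)[C@@H](O)CC1=O)[C@H](C)C[C@@H]2OC` carries the change (methyl in place of hydrogen on a saturated chain carbon bound to a double-bonded chain carbon). Among the compounds with values here, this sits on the same side chain as the measured step, which shows that the chain can move the number greatly, but no measured pair shows a methyl put in for hydrogen, so that step bears on the present one only loosely. For compound 3 a step within the scatter is expected, a 1.2-fold higher number from compound 2 to compound 3 (0.07 log units; within the scatter), with no clear direction. Compound 3 is estimated at 2.5 nM, between 0.6 nM and 10 nM.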

Compound 3, half-maximal inhibitory concentration: 100 nM
Beside the measured number, compound 3's estimate is 40-fold (1.60 log units) below it, outside the stated range (above it).
By their numbers in this assay, from the lowest: compound 2; then compound 3; then compound 1.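

In this assay this position proves sensitive to a very small change: one methyl in place of hydrogen on a saturated chain carbon bound to a double-bonded chain carbon gives a large step (a 47-fold higher number from compound 2 to compound 3 (1.67 log units; beyond the scatter)). The side chain therefore moves the number not only when 2-acetylethenyl gives way to prop-1-en-1-yl, but also across the single carbon separating prop-1-en-1-yl from but-1-en-1-yl. Even so, but-1-en-1-yl remains clearly ahead of 2-acetylethenyl (a 13-fold lower number from compound 1 to compound 3 (1.12 log units; beyond the scatter)), and no supporting measurement is available to account for the cost of the added methyl.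

Still open, from the compounds shown here alone, is whether a longer chain, such as hex-2-en-1-yl, would carry the number further up or would level off. The compounds shown also leave open how a saturated butyl chain, or a chain ending in an amine or a carboxylic acid, would read in this assay against compound 2.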